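The source may hold more compounds than are shown below. What is called first, only, known or untested is meant among the compounds shown, and "the series" means these compounds.

In a functional assay on VCaP cells (Homo sapiens) for antiproliferative activity, read by CCK-8 assay, with a stated time of 6 days (a higher number here means a weaker inhibitor, a lower number a stronger inhibitor), compound 1 `C[C@@H](Cn1ccc(-c2ccc(C#N)c(Cl)c2)n1)Nc1cncnc1` reads > 30000 nM, which is a limit of the assay and not a number. Within the data shown here, compound 2 `C[C@@H](Cn1ccc(-c2ccc(C#N)c(Cl)c2)n1)Nc1ncnc2nc[nH]c12` gives 640 nM, the lowest number so far. Compound 3 `C[C@H](Cn1ccc(-c2ccc(C#N)c(Cl)c2)n1)Nc1ncnc2nc[nH]c12` gives 2000 nM; (the fact that compounds 2 and 3 differ only in the configuration as drawn). Changing the group on the amine nitrogen gave an at least 46-fold lower number from compound 1 to compound 2 (1.67 log units; beyond the scatter), a large step, and changing the stereocentre gave a 3.1-fold higher number from compound 2 to compound 3 (0.49 log units; beyond the scatter), a modest one. Compound 4 `C[C@@H](Cn1ccc(-c2ccc(C#N)c(Cl)c2)n1)Nc1nc(Cl)nc2nc[nH]c12` carries chloro in place of hydrogen on an aromatic carbon, between two ring nitrogen atoms. Neither measured step touches this carbon, so they offer only loose guidance, and the direction remains uncertain. The expected outcome is a 1.3-fold lower number from compound 2 to compound 4 (0.11 log units; within the scatter), a small step at most. For compound 4 the estimated value is 500 nM, with an expected range of 120 nM to 2000 nM.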

Compound 4, half-maximal inhibitory concentration: 2700 nM
Beside the measured number, compound 4's estimate is 5.4-fold (0.73 log units) below it; the whole stated range lies below it.
By their numbers in this assay, from the lowest: compound 2; then compounds 3 and 4 (each within the scatter of the next). At a limit, above all of these: compound 1.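

In this assay, the aromatic carbon between two ring nitrogen atoms proves sensitive: chloro in place of hydrogen gives a 4.2-fold higher number from compound 2 to compound 4 (0.63 log units; beyond the scatter). Among these compounds, the earlier steps concerned the group on the amine nitrogen and the stereocentre, so this is the first reading at this carbon, and a single added atom moves the number beyond the scatter. Nothing measured here explains this rise. From the compounds shown here alone, whether it is particular to chloro or would follow any group on this carbon stays open. An amine or a methyl group there could help separate these two readings.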